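The source may hold more compounds than are shown below. What is called first, only, known or untested is meant among the compounds shown, and "the series" means these compounds.

Compound 1 `O=C(Nc1cccc(-c2nc3ccccc3s2)c1)c1cnccc1Cl` stands in an ADME assay on BJ cells (Homo sapiens) for inhibition, with a stated time of 72 h (a higher number here means that more compound is needed for the effect, a lower number that less compound is needed), only at a limit, > 25000 nM. Compound 2 `O=C(Nc1cccc(-c2nc3ccccc3s2)c1)c1ccncc1Cl`, also measured in this assay, gives a limit as well, > 25000 nM. Among the measured compounds shown here, the step from compound 1 to compound 2 in this assay is therefore a step that the two limits leave unreadable from compound 1 to compound 2, and the only evidence is the limit of > 25000 nM in this assay, at which 2 of the 2 values shown sit.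

Compound 3 `O=C(Nc1ccc(F)c(-c2nc3ccccc3s2)c1)c1cnccc1Cl` differs from compound 1 by fluoro in place of hydrogen on an aromatic carbon. For the measured compounds named here, no measured step touches this change, and the one step recorded is unreadable. Compound 3 is expected to remain at the limit in this assay, with an estimate of 30000 nM, between 8000 nM and 100000 nM, a step that the limit leaves unreadable from compound 1 to compound 3.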

Compound 3, half-maximal effective concentration: > 25000 nM
Compound 3: a limit, no number (the forecaster's own chance of this, stated with the estimate: 80%); the middle value is on the limit's open side.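

Among the compounds shown here, compound 3 stands at a limit in this assay, > 25000 nM, so no step from compound 1 to compound 3 can be read. The compounds shown leave open what concentration any of them needs for the effect, and whether either change shifts it.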